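Dropping the ethylcarbamoyl group from compound 2

The compounds below may be only part of what the source reports. "The series", "measured", "known", "first", "only" and "open" are said of these compounds alone.

Among the compounds with values here, in a functional assay on NCI-H1975 cells (Homo sapiens) for antiproliferative activity, with a stated time of 72 h (on this read-out higher numbers stand for weaker inhibition of growth and lower numbers for stronger inhibition of growth), only two compounds have numbers so far. Compound 1 (`O=C(NCc1ccccc1)c1cc(Cl)c(O)cc1O`) gives 86200 nM and compound 2 (`CCNC(=O)c1ccc(CN(C)C(=O)c2cc(Cl)c(O)cc2O)cc1`) gives 21700 nM as the lower of the two numbers, with a gap beyond the usual scatter. Compound 3 (`CN(Cc1ccccc1)C(=O)c1cc(Cl)c(O)cc1O`) is still unmeasured. It is compound 2 with hydrogen in place of ethylcarbamoyl on an aromatic carbon, para to a large group. Within the data shown here, no measured pair shows this change alone. Compound 1 also lacks ethylcarbamoyl and gives 86200 nM as a higher number, so a moderate rise is expected, which would mean weaker inhibition of growth. The expected size is a 2.3-fold higher number from compound 2 to compound 3 (0.36 log units; beyond the scatter) in this assay as a rough estimate. For compound 3 the estimate is 50000 nM with an expected range from 18000 nM to 110000 nM in this assay for now.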

Compound 3, concentration for 50% growth inhibition: 35500 nM
Compound 3: middle estimate off by 1.4-fold (0.15 log units), on the high side; the range from low to high includes it.
By their numbers in this assay, from the lowest: compounds 2 and 3 (each within the scatter of the next); then compound 1.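

In this assay, there is a 1.6-fold higher number from compound 2 to compound 3 (0.21 log units; within the scatter) when the ethylcarbamoyl group on the aromatic carbon para to a large group gives way to hydrogen, so compound 2 and compound 3 cannot be told apart at this position. Within the data shown here, the single change on the amide-type nitrogen gives a 2.4-fold lower number from compound 1 to compound 3 (0.39 log units; beyond the scatter), a modest step beyond the scatter, and of the two steps it is the only one that clearly moves the read-out. Nothing measured here offers an explanation for either step.

A carboxylic acid or an amine at the same aromatic carbon could behave differently from ethylcarbamoyl, and an ethyl group on the amide nitrogen would test more than methyl alone. As far as these compounds go, it also remains open whether methyl in place of the amide hydrogen would have the same effect with ethylcarbamoyl present.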